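Sulfonamide Diamines Against Neuroblastoma Cells: A Tail Exchange

A few compounds are considered here, and "the series" means these few. Any claim that something is new, unique, unknown or untested is made for them only; others in the source may bear on it.

Three sulfonamide-linked diamines have been measured in a functional assay on BE(2)-C cells (Homo sapiens) for inhibition, read by MTT assay, with a stated time of 72 h; on this read-out higher numbers stand for weaker inhibition of growth and lower numbers for stronger inhibition of growth. Compound 1 `CC(C)(C)c1ccc(CNCCCNS(=O)(=O)c2cc(C(F)(F)F)cc(C(F)(F)F)c2)cc1` gives 2500 nM, which is the lowest of the three numbers, though its nearest neighbour, compound 3 `O=S(=O)(NCCCNCc1ccc(-c2ccccc2)cc1)c1cc(C(F)(F)F)cc(C(F)(F)F)c1`, gives 2600 nM and is within the scatter of it. Compound 2 `O=S(=O)(NCCNCc1cccc2ccccc12)c1cc(C(F)(F)F)cc(C(F)(F)F)c1` gives 19000 nM, well apart from the other two, but it differs from compound 1 in more than one place, so only the two values themselves can be compared. Going by the values given here, the single measured step, a 1.0-fold higher number from compound 1 to compound 3 (0.02 log units; within the scatter), shows that exchanging the group on the aryl tail left the growth inhibition unchanged.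

Compound 4 `O=S(=O)(NCCCNCc1ccc(Cl)c(C(F)(F)F)c1)c1cc(C(F)(F)F)cc(C(F)(F)F)c1` has not yet been measured in this assay. It differs from compound 1 by 4-chloro-3-(trifluoromethyl)phenyl in place of 4-(tert-butyl)phenyl on a saturated chain carbon bound to an amine nitrogen. Among the compounds with values here, the only relevant measured step, the change from compound 1 to compound 3, lay within the scatter, so the tail appears tolerant of substitution there. Compound 4 is therefore expected to fall close to compound 1, with a step of a 1.2-fold higher number from compound 1 to compound 4 (0.08 log units; within the scatter) and an estimated value of 3000 nM, in the range 1200 nM to 8000 nM.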

Compound 4, concentration for 50% growth inhibition: 8600 nM
Beside the measured number, compound 4's estimate is 2.9-fold (0.46 log units) below it; the measured number lies above the stated range.
By their numbers in this assay, from the lowest: compounds 1 and 3 (each within the scatter of the next); then compound 4; then compound 2.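

In this assay the exchange on the saturated chain carbon bound to an amine nitrogen gives a 3.4-fold higher number from compound 1 to compound 4 (0.54 log units; beyond the scatter) with 4-chloro-3-(trifluoromethyl)phenyl in place of 4-(tert-butyl)phenyl, so the tail at this position is not indifferent to what it carries. The earlier step, a 1.0-fold higher number from compound 1 to compound 3 (0.02 log units; within the scatter) and within the scatter, had shown no such sensitivity, whereas this modest step lies beyond the scatter and gives the series its first one-place change that moves the growth inhibition. Nothing at hand accounts for this weaker growth inhibition.

Going by these compounds, it remains open whether the chlorine or the trifluoromethyl group carries the step, for the two enter together in compound 4. Also open, on these data alone, is how a tail bearing an amine or a methoxy group, or a longer chain in the linker, would read in this assay here.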